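From Cyclopentyloxy to (2-Chlorobenzyl)sulfanyl: Estimating Compound 4

The source may hold more compounds than are shown below. What is called first, only, known or untested is meant among the compounds shown, and "the series" means these compounds.

Compound 1 `CC(C(=O)NCc1ccc(C(C)(C)C)nc1N1CCCCCC1)c1ccc(NS(C)(=O)=O)c(F)c1` gives 0.9 nM
Compound 2 `CC(C(=O)NCc1ccc(C(C)(C)C)nc1N1CCC(Cc2ccccc2)CC1)c1ccc(NS(C)(=O)=O)c(F)c1` gives 0.3 nM
Compound 3 `CC(C(=O)NCc1ccc(C(C)(C)C)nc1OC1CCCC1)c1ccc(NS(C)(=O)=O)c(F)c1` gives 1.5 nM

In an assay on cells for antagonist activity at transient receptor potential cation channel subfamily V member 1 (Homo sapiens), read by FLIPR and calcium flux, with a stated time of 6 min (on this read-out higher numbers stand for weaker inhibition and lower numbers for stronger inhibition), compound 3 has the highest of the three numbers, although its gap to compound 1 is within the scatter; only compound 2 lies beyond it. Compound 4 `CC(C(=O)NCc1ccc(C(C)(C)C)nc1SCc1ccccc1Cl)c1ccc(NS(C)(=O)=O)c(F)c1` differs from compound 3 in one place: (2-chlorobenzyl)sulfanyl in place of cyclopentyloxy on an aromatic carbon. For the measured compounds named here, one measured step bears on this position, a 1.7-fold higher number from compound 1 to compound 3 (0.22 log units; within the scatter), and it stayed within the scatter, so changes of the group there have so far moved the number little. Going by the values given here, no measured compound carries a sulfur link or a chlorine here. A small move to a lower number is therefore expected for compound 4, a 1.7-fold lower number from compound 3 to compound 4 (0.22 log units; within the scatter), likely within the scatter. Compound 4 is estimated at 0.9 nM, between 0.25 nM and 3.5 nM.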

Compound 4, inhibition constant: 3.8 nM
Compound 4: the middle estimate sits 4.2-fold (0.63 log units) below what was measured, outside the stated range (above it).
By their numbers in this assay, from the lowest: compound 2; then compounds 1 and 3 (each within the scatter of the next); then compound 4.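

This position tolerates less than compound 1 and compound 3 alone suggested: with (2-chlorobenzyl)sulfanyl there is a 2.5-fold higher number from compound 3 to compound 4 (0.40 log units; beyond the scatter) and also a 4.2-fold higher number from compound 1 to compound 4 (0.63 log units; beyond the scatter). Both steps are modest but lie beyond the scatter, so a change of group here can measurably weaken inhibition. No supporting data explain this shift.

Still open, as far as these compounds go, is which part of the new group matters, the sulfur link, the chlorine or the benzyl ring. A plain benzylsulfanyl group or a 2-chlorobenzyloxy group, with oxygen as the link, would begin to separate them.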